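Loss of one chloro on the benzyl arm of a dioxygenase inhibitor

This account rests on a few compounds, and the source may have more. Where it says the series, first, only, none or still open, it means among the compounds named here.

Measured compounds:
compound 1, `Cc1[nH]n(-c2nc3ccccc3[nH]2)c(=O)c1Cc1ccc(Cl)cc1`, > 10000 nM
compound 2, `Cc1ccc2[nH]c(-n3[nH]c(C)c(Cc4ccc(Cl)c(Cl)c4)c3=O)nc2c1`, 720 nM

Of the compounds shown here, two have been measured in an assay on isolated protein for inhibition of alpha-ketoglutarate-dependent dioxygenase alkB homolog 3 (Homo sapiens), read by polymerase chain reaction, with a stated time of 1 h; a higher number here means a weaker inhibitor, a lower number a stronger inhibitor. For compound 1 the result is a limit of the assay, not a number: compound 1 gives > 10000 nM, which is the limit of > 10000 nM in this assay, at which 1 of the 2 values shown sits. Among the measured compounds shown here, compound 2 gives 720 nM in this assay, and this is the only numeric value shown, so compound 2 stands alone as the reference point; no step between measured compounds is available, and compound 1 differs from the others in more than one place.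

Compound 3, `Cc1ccc2[nH]c(-n3[nH]c(C)c(Cc4ccc(Cl)cc4)c3=O)nc2c1`, is yet to be measured. It differs from compound 2 by hydrogen in place of chloro on an aromatic carbon, or, cut one bond further out, 3,4-dichlorophenyl to 4-chlorophenyl. Nothing measured tells how much that chloro contributes. A step from compound 2 to compound 3 of a 4.2-fold higher number from compound 2 to compound 3 (0.62 log units; beyond the scatter) is expected, in the direction of weaker inhibition, modest but likely beyond the scatter. Compound 3 is therefore estimated at 3000 nM in this assay, within 1000 nM to 10000 nM.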

Compound 3, half-maximal inhibitory concentration: 750 nM
Beside the measured number, compound 3's estimate is 4.0-fold (0.60 log units) above it, and the stated range ends above it.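

In this assay, the step for hydrogen in place of chloro on an aromatic carbon is a 1.0-fold higher number from compound 2 to compound 3 (0.02 log units; within the scatter), so compound 2 and compound 3 cannot be told apart, and at this carbon of the 3,4-dichlorophenyl arm the chloro can be lost with no measurable cost. The one place that separates the 4-chlorophenyl compounds is instead methyl in place of hydrogen on an aromatic carbon of the core, with an at least 13-fold lower number from compound 1 to compound 3 (1.12 log units; beyond the scatter), which gives the first readable sign that this methyl matters more in this assay than the chloro does. Compound 1 sits at a limit of the assay, so that step gives only a bound and not a size: the limit of > 10000 nM in this assay, at which 1 of the 3 values shown sits.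

The compounds shown leave open whether the remaining chloro of the 4-chlorophenyl arm contributes anything, since no compound has an unsubstituted phenyl, a fluoro or a methoxy there. They also leave open how far the methyl on the core can be varied, for example whether an ethyl, a methoxy or a carboxylic acid at that carbon would hold the value of compound 3.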